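This account rests on a few compounds, and the source may have more. Where it says the series, first, only, none or still open, it means among the compounds named here.

Of the compounds shown here, two have so far been tested in a functional assay on the whole organism (strain albino) for inhibition, with Rattus norvegicus as the target, read by paw edema, with stated times of 30 min and 1 h, at a dose of 100 mg/kg by the oral route; on this read-out lower numbers stand for less inhibition and higher numbers for more inhibition at the one dose given (going by the name of the read-out). Compound 1, `CC(O[N+](=O)[O-])C(=O)Nc1ccc(C(=O)/C=C/c2ccco2)cc1`, gives 41% in this assay. Compound 2, `O=C(COCc1c(-c2ccccc2)no[n+]1[O-])Nc1ccc(C(=O)/C=C/c2ccc(Cl)cc2)cc1`, gives 38% in this assay. Of the two numbers, that of compound 2 is the smaller, but its gap to compound 1 lies within the usual scatter of repeated measurements, so the two compounds cannot be told apart on this read-out.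

Compound 3, `COc1ccc(/C=C/C(=O)c2ccc(NC(=O)COCc3c(-c4ccccc4)no[n+]3[O-])cc2)cc1`, has not yet been measured in this assay. It differs from compound 2 in one place: methoxy in place of chloro on an aromatic carbon. The exchange sits on an aromatic carbon of a six-membered aromatic ring of carbon only, and the rest of the molecule stays the same.

Among the compounds with values here, no measured pair in this set shows what this exchange does to the read-out, so there is no step to lean on. The step from compound 2 to compound 3 is therefore expected to be no change at the digits printed from compound 2 to compound 3 (within the scatter), with no movement beyond the scatter in either direction. On that basis compound 3 is estimated to give 38% in this assay, expected to fall between 25% and 51%.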

Compound 3, a percentage reported as inhibition, in the whole organism at one dose (the size of the read-out at that dose, not a potency): 30%
For compound 3 the middle estimate is 8 percentage points above the measured one; measured number inside the range.
By their numbers in this assay, from the lowest: compounds 3, 2 and 1 (each within the scatter of the next, the first and the last beyond it).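

Within the data shown here, putting methoxy in place of chloro on the aromatic carbon para to a large group gives a number 8 percentage points lower from compound 2 to compound 3 (within the scatter) in this assay, the first step in this set that isolates a single exchange. At this one dose, then, a 4-chlorophenyl and a 4-methoxyphenyl at this end of the molecule cannot be told apart, although the entering group brings 2 heavy atoms against 1 and 1 hydrogen-bond acceptor against 0. Nothing available here accounts for this result or tells what either group does in the animal.

A single exchange at a single dose cannot show whether this position accepts any group or only these two, so an amine, a carboxylic acid or a longer chain such as butoxy in the same place might still move the number beyond the scatter. Going by these compounds, it also remains open whether methoxy in place of chloro would give a similar step on a different core, or whether a real difference between these two compounds would emerge across several doses.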